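Adding a Nitrile to Compound 1

The source may report more compounds than this note shows. Statements on the series, on what has been measured and on what is new or still open speak of the compounds shown alone.

Among the measured compounds shown here, compound 1 `CCOc1cc(NC(=O)NCc2cc(C)c(-c3cn(C)nc3C(F)(F)F)nn2)cc(C)n1` gives the highest number of the two measured so far: in a functional assay on CHO cells for antagonist activity at sphingosine 1-phosphate receptor 2 (Homo sapiens), read by fluorescence and calcium flux, with a stated time of 3 min (on this read-out higher numbers stand for weaker inhibition and lower numbers for stronger inhibition), compound 1 gives 54000 nM. Its nearest neighbour, compound 2 `CCOc1nc(Cl)cc(NC(=O)NCc2cc(C)c(-c3cn(C)nc3C(F)(F)F)nn2)c1C`, gives 8800 nM, and the change a 6.1-fold lower number from compound 1 to compound 2 (0.79 log units; beyond the scatter) is modest yet beyond the scatter. Compound 3 `CCOc1nc(C)cc(NC(=O)NCc2cc(C)c(-c3cn(C)nc3C(F)(F)F)nn2)c1C#N` differs from compound 1 by cyano in place of hydrogen on an aromatic carbon. For the measured compounds named here, no measured step matches this change directly. The step from compound 1 to compound 2 altered the same ring and lowered the number. A smaller shift in the same direction is expected for compound 3, a 2.7-fold lower number from compound 1 to compound 3 (0.43 log units; beyond the scatter). Compound 3 is therefore estimated at 20000 nM, within 6000 nM to 60000 nM.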

Compound 3, half-maximal inhibitory concentration: > 20000000 nM
Compound 3: only a limit was reported (the forecaster's own chance of this, stated with the estimate: 10%); middle value at least 1000-fold (3.00 log units) away from the limit.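

Cyano in place of hydrogen on this aromatic carbon, ortho to an ethoxy group and para to a methyl group, moves the number sharply upward in this assay, the step being an at least 370-fold higher number from compound 1 to compound 3 (2.56 log units; beyond the scatter). The earlier change to the same ring had gone the other way, a 6.1-fold lower number from compound 1 to compound 2 (0.79 log units; beyond the scatter), so changes to this ring do not all lower the number. Compound 3 has only a limit, not a number: the limit of > 20000000 nM in this assay, at which 1 of the 3 values shown sits.

From the compounds shown here alone, whether this rise belongs to the cyano group itself or to any group on this carbon stays open. An amine, a methyl group or a single fluorine atom here would separate the two.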